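A Five-Membered Aromatic Ring Replaces the Methoxyethyl Chain

This account rests on a few compounds, and the source may have more. Where it says the series, first, only, none or still open, it means among the compounds named here.

Compound 1 `CCN(Cc1cccs1)C(=O)COc1ccc(C)cc1` gives 8 nM in an assay on HEK293 cells for agonist activity at transient receptor potential cation channel subfamily M member 8 (Homo sapiens), read by fluorescence and calcium flux, with a stated time of 15 min; a higher number here means that more compound is needed for the effect, a lower number that less compound is needed.
Compound 2 `CCC(C)N(Cc1cccs1)C(=O)COc1ccc(C)cc1` gives 2000 nM in this assay.
Compound 3 `COCCN(Cc1cccs1)C(=O)COc1ccc(C)cc1` gives 400 nM in this assay.

Compound 3 stands second highest of the three numbers: a 50-fold higher number from compound 1 to compound 3 (1.70 log units; beyond the scatter), while a 5.0-fold lower number from compound 2 to compound 3 (0.70 log units; beyond the scatter). Compound 4 `Cc1ccc(OCC(=O)N(Cc2cccs2)c2ccon2)cc1` differs from compound 3 in one place: 1,2-oxazol-3-yl in place of 2-methoxyethyl on an amide-type nitrogen. The measured steps all concern the group on this nitrogen. Going by the values given here, both a 250-fold higher number from compound 1 to compound 2 (2.40 log units; beyond the scatter) and a 50-fold higher number from compound 1 to compound 3 (1.70 log units; beyond the scatter) were large, so the number in this assay is sensitive to what sits there, but none of the measured groups is an aromatic ring, so the direction for compound 4 is uncertain. A step of either sign of modest size is expected, a 1.3-fold lower number from compound 3 to compound 4 (0.12 log units; within the scatter). Compound 4 is therefore estimated at 300 nM in this assay, within 30 nM to 3000 nM.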

Compound 4, half-maximal effective concentration: 2 nM
Beside the measured number, compound 4's estimate is 150-fold (2.18 log units) above it, outside the stated range (below it).
By their numbers in this assay, from the lowest: compound 4; then compound 1; then compound 3; then compound 2.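

With 1,2-oxazol-3-yl on the amide-type nitrogen, this assay shows that this position tolerates an aromatic ring: the change gives a 200-fold lower number from compound 3 to compound 4 (2.30 log units; beyond the scatter), and the comparison with sec-butyl gives a 1000-fold lower number from compound 2 to compound 4 (3.00 log units; beyond the scatter). The ring also outdoes ethyl, the best of the earlier groups, with a 4.0-fold lower number from compound 1 to compound 4 (0.60 log units; beyond the scatter), although it carries more heavy atoms than 2-methoxyethyl. No measurement available here explains this gain. The compounds shown leave open whether any aromatic ring would serve at this position or only this arrangement of hetero atoms, as phenyl or 1,3-thiazol-2-yl on the same nitrogen would show.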